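A few compounds are considered here, and "the series" means these few. Any claim that something is new, unique, unknown or untested is made for them only; others in the source may bear on it.

Measured compounds:
compound 1, `O=C1O/C(=C\Cn2cc(-c3ccc(Br)cc3)nn2)C(OCc2ccccc2)=C1OCc1ccccc1`, > 100000 nM;
compound 2, `O=C1O/C(=C\Cn2cc(-c3cc(F)cc(F)c3)nn2)C(OCc2ccccc2)=C1OCc1ccccc1`, > 100000 nM;
compound 3, `O=C1O[C@H]([C@@H](O)Cn2cc(CCCCl)nn2)C(OCc2ccccc2)=C1OCc1ccccc1`, 35000 nM.

In a functional assay on HepG2 cells (Homo sapiens) for antiproliferative activity, read by MTT assay, with a stated time of 72 h (on this read-out lower numbers stand for stronger inhibition and higher numbers for weaker inhibition), compound 2 stands at a limit of the assay, not at a number. Compound 1 likewise stands at a limit in this assay. Only compound 3 gives a measured number in this assay. The step from compound 1 to compound 2 is therefore a step that the two limits leave unreadable from compound 1 to compound 2; its size cannot be read because of the limit of > 100000 nM in this assay, at which 2 of the 3 values shown sit. The unmeasured compound 4, `O=C1O/C(=C\Cn2cc(-c3cccc(O)c3)nn2)C(OCc2ccccc2)=C1OCc1ccccc1`, differs from compound 2 by 3-hydroxyphenyl in place of 3,5-difluorophenyl on an aromatic carbon. Among the compounds with values here, no measured step bears on this change, and both aromatic variants so far sit at the limit. Compound 4 is therefore expected to stay near that limit, an estimated 100000 nM between 30000 nM and 300000 nM, a step of a number no higher from compound 2 to compound 4 (the limit leaves the size open).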

Compound 4, half-maximal inhibitory concentration: 61700 nM
For compound 4 the middle estimate is 1.6-fold (0.21 log units) above the measured one; measured number inside the range.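

At this aromatic carbon, 3-hydroxyphenyl gives the only aryl variant shown with a measured number in this assay, with compound 4 at 61700 nM. The change gives an at least 1.6-fold lower number from compound 2 to compound 4 (0.20 log units; that floor lies within the scatter), and the exchange for 4-bromophenyl gives an at least 1.6-fold lower number from compound 1 to compound 4 (0.20 log units; that floor lies within the scatter). Both steps are only floors, and their true sizes stay open because of a limit: the limit of > 100000 nM in this assay, at which 2 of the 4 values shown sit.

The compounds shown do not separate the entry of the hydroxyl group from the loss of the two fluorines or the bromine. Going by these compounds, what an aminophenyl or carboxyphenyl group would give at this carbon also remains open.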